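Trading the ethoxy for an ethyl on the aromatic ring

A few compounds are considered here, and "the series" means these few. Any claim that something is new, unique, unknown or untested is made for them only; others in the source may bear on it.

Compound 3 `CCOc1ccc(Cl)c(C(=O)NC(=O)Nc2nc3ccc(S(=O)(=O)CCCN4CCN(C)CC4)cc3s2)c1` is one of three close analogues measured in an assay on HEK293 cells for displacement of a labelled ligand from growth hormone secretagogue receptor type 1 (Homo sapiens), with a stated time of 60 min (a higher number here means a weaker inhibitor, a lower number a stronger inhibitor), where compound 3 gives 0.31 nM. Going by the values given here, on the numbers so far it stands second highest of three: compound 1 `CN1CCN(CCCS(=O)(=O)c2ccc3nc(NC(=O)NC(=O)c4cc(C5CC5)ccc4Cl)sc3c2)CC1` gives 0.33 nM in this assay, and compound 2 `CN1CCN(CCCS(=O)(=O)c2ccc3nc(NC(=O)NC(=O)c4cc(-n5cccc5)ccc4Cl)sc3c2)CC1` gives 0.15 nM. The steps between them are modest at most: a 1.1-fold lower number from compound 1 to compound 3 (0.03 log units; within the scatter), while a 2.1-fold higher number from compound 2 to compound 3 (0.32 log units; beyond the scatter) and a 2.2-fold lower number from compound 1 to compound 2 (0.34 log units; beyond the scatter).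

Compound 4 `CCc1ccc(Cl)c(C(=O)NC(=O)Nc2nc3ccc(S(=O)(=O)CCCN4CCN(C)CC4)cc3s2)c1` has not yet been measured. It differs from compound 3 in one place: ethyl in place of ethoxy on an aromatic carbon. Among the compounds with values here, none of the measured steps involves an ethyl group, so the nearest guide is the exchange of cyclopropyl for ethoxy on an aromatic carbon, a 1.1-fold lower number from compound 1 to compound 3 (0.03 log units; within the scatter), which stayed within the scatter; only the 1H-pyrrol-1-yl analogue, compound 2, moved beyond it. Given a 1.1-fold lower number from compound 1 to compound 3 (0.03 log units; within the scatter), two rather different groups on that aromatic carbon returned nearly the same number, and the step to the ethyl analogue is therefore expected to be a 1.1-fold higher number from compound 3 to compound 4 (0.05 log units; within the scatter), a change that should stay within the scatter rather than beyond it. Compound 4 is accordingly estimated to give 0.35 nM in this assay, with a likely range from 0.15 nM to 0.8 nM.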

Compound 4, half-maximal inhibitory concentration in the growth hormone secretagogue receptor type 1 assay: 0.078 nM
Estimate against measurement, compound 4: 4.5-fold (0.65 log units) above; measured number below the stated range.
By their numbers in the growth hormone secretagogue receptor type 1 assay, from the lowest: compounds 4 and 2 (each within the scatter of the next); then compounds 3 and 1 (each within the scatter of the next).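

The position para to a chloro group turns out to respond to the choice of substituent, even though cyclopropyl and ethoxy had given matching numbers there: in the growth hormone secretagogue receptor type 1 assay the ethyl group gives a 4.0-fold lower number from compound 3 to compound 4 (0.60 log units; beyond the scatter) and a 4.2-fold lower number from compound 1 to compound 4 (0.63 log units; beyond the scatter). In the growth hormone secretagogue receptor type 1 assay it cannot be told apart from the 1H-pyrrol-1-yl group, with a 1.9-fold lower number from compound 2 to compound 4 (0.28 log units; within the scatter), so the four compounds fall into two groups of two, with the ethyl and 1H-pyrrol-1-yl analogues on the lower side. The same exchange, which removes the oxygen of the ethoxy group, also moves the distribution coefficient: in a physicochemical assay for lipophilicity (a lower number here means a more polar compound, a higher number a more lipophilic compound), compound 3 gives 2.4 and compound 4 gives 2.9, a number 0.50 log units higher from compound 3 to compound 4 (beyond the scatter).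

With this single pair, the compounds shown cannot separate the loss of that oxygen from the rise in distribution coefficient as the source of the lower number in the growth hormone secretagogue receptor type 1 assay. As far as these compounds go, whether a methoxy or a propyl group on the same carbon would land with compound 3 or with compound 4 also remains open.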